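The source may report more compounds than this note shows. Statements on the series, on what has been measured and on what is new or still open speak of the compounds shown alone.

Measured compounds:
Compound 1 `CCc1cccc(C2=CCN(S(=O)(=O)N3CCCC[C@@H]3C(=O)NO)CC2)c1` gives 320 nM in a functional assay on MONO-MAC-6 cells (Homo sapiens) for inhibition; a lower number here means a stronger inhibitor, a higher number a weaker inhibitor.
Compound 2 `O=C(NO)[C@H]1CNCCN1S(=O)(=O)N1CC=C(c2ccc(F)cc2)CC1` gives 3560 nM in this assay.
Compound 3 `CN(C)C(=O)N1CCN(S(=O)(=O)N2CC=C(c3ccc(F)cc3)CC2)[C@@H](C(=O)NO)C1` gives 200 nM in this assay.

Compound 3 has the lowest of the three numbers, with compound 1 within the scatter of it and compound 2 well beyond. Compound 4 `CNC(=O)N1CCN(S(=O)(=O)N2CC=C(c3ccc(F)cc3)CC2)[C@@H](C(=O)NO)C1` differs from compound 3 by hydrogen in place of methyl on an amide-type nitrogen. For the measured compounds named here, the one measured step that touches this region, an 18-fold lower number from compound 2 to compound 3 (1.25 log units; beyond the scatter), installed the whole dimethylcarbamoyl group on a bare ring amine and was large; trimming one methyl from that group is a far smaller change. Going by the values given here, no step isolating a single methyl on this nitrogen exists, so compound 4 is expected to show a 1.5-fold higher number from compound 3 to compound 4 (0.18 log units; within the scatter), at most a modest weakening. Compound 4 is therefore estimated at 300 nM, with a range from 120 nM to 800 nM.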

Compound 4, half-maximal inhibitory concentration: 120 nM
Compound 4: the middle estimate sits 2.5-fold (0.40 log units) above what was measured, within the range that was stated.
By their numbers in this assay, from the lowest: compounds 4, 3 and 1 (each within the scatter of the next, the first and the last beyond it); then compound 2.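

In this assay, the step with hydrogen in place of methyl on this amide-type nitrogen, a 1.7-fold lower number from compound 3 to compound 4 (0.22 log units; within the scatter), shows that the second methyl of the dimethylcarbamoyl group can go without a change beyond the scatter. The methylcarbamoyl group alone also accounts for a large step on the ring amine nitrogen, a 30-fold lower number from compound 2 to compound 4 (1.47 log units; beyond the scatter), so the large gain does not depend on having both methyls. Nothing available gives a reason for these numbers. Still open, going by these compounds, is how an ethyl or longer chain on this nitrogen would read. On these data alone, an acetyl group or a carboxylic acid in place of the carbamoyl group also remains open.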